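Removing a methoxy group: an expected flat step in lipophilicity

This account rests on a few compounds, and the source may have more. Where it says the series, first, only, none or still open, it means among the compounds named here.

Measured compounds:
Compound 1, `COc1ccc(/C=C2\CCC/C(=C\c3ccccc3[N+](=O)[O-])C2=O)cc1`, gives 4.86 in a physicochemical assay for lipophilicity; on this read-out higher numbers stand for higher lipophilicity and lower numbers for lower lipophilicity.
Compound 2, `O=C1/C(=C/c2ccccc2)CCC/C1=C\c1cccc([N+](=O)[O-])c1`, gives 5.06 in this assay.

Compound 1 holds the lower of the two numbers in this assay, with compound 2 the nearer of the two; the two values lie within the scatter of each other, so the data show no difference between them in this assay.

The step followed here runs from compound 1 to compound 3, `O=C1/C(=C/c2ccccc2)CCC/C1=C\c1ccccc1[N+](=O)[O-]`, which has not yet been measured in this assay. The change is hydrogen in place of methoxy on an aromatic carbon. It sits on an aromatic carbon of a six-membered aromatic ring of carbon only, para to a large group.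

For the measured compounds named here, no step between two measured compounds is recorded for this change, so there is nothing in the set to calibrate it. The expectation is a step of a number 0.01 log units lower from compound 1 to compound 3 (within the scatter) from compound 1 to compound 3, that is, no change beyond the scatter in either direction. Compound 3 is therefore estimated at 4.85 in this assay, within a range of 4.5 to 5.2.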

Compound 3, partition coefficient: 4.86
Beside the measured number, compound 3's estimate is 0.01 log units below it, within the range that was stated.
By their numbers in this assay, from the lowest: compounds 1, 3 and 2 (each within the scatter of the next).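

In this assay, for the compounds shown here, hydrogen in place of methoxy on an aromatic carbon, para to a large group, gives no change at the digits printed from compound 1 to compound 3 (within the scatter), and this is the only measured step in the set that isolates this change. It shows that, at this position on the six-membered aromatic ring of carbon only, going from 4-methoxyphenyl to phenyl leaves the read-out within the scatter, something the earlier pair could not show, as compound 1 and compound 2 differ in more than one place. Nothing in the data gives a reason for the size of this step.

The compounds shown hold only this one replacement at this position, so it stays open whether a hydroxyl group, an amine, a carboxylic acid or a longer chain such as butoxy in the same place would also stay within the scatter of compound 1. One pair also leaves open whether hydrogen in place of methoxy gives a similar step on a different core or elsewhere on this one.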